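The source may hold more compounds than are shown below. What is called first, only, known or untested is meant among the compounds shown, and "the series" means these compounds.

Among the compounds with values here, compound 1 `Cn1c(CN2C[C@@H]3C(COc4ccccc4)[C@@H]3C2)nc2ccccc21` is the one member of this small set with a plain number in an in vitro ADME assay on microsomes from liver (Homo sapiens) for metabolic stability, tested at 1 uM; on this read-out higher numbers stand for fast clearance and lower numbers for slow clearance: compound 1 gives 14.2 mL/min/kg. Compound 2 `c1ccc(OCC2[C@H]3CN(Cc4cn5ccccc5n4)C[C@@H]23)cc1` has no result in this assay, and its entry for compound 2 reads "not determined" (no result reported). Compound 3 `c1ccc(OCC2[C@H]3CN(Cc4cnc5ccccc5c4)C[C@@H]23)cc1` reached only a limit of the assay, and that limit for compound 3 is < 5.3 mL/min/kg; this is the cut-off described as the limit of < 5.3 mL/min/kg in this assay, at which 1 of the 3 values shown sits. Within the data shown here, compound 1 therefore stands as the only measured number, with one limit and one missing entry beside it.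

Compound 4 `Cn1c(CN2C[C@@H]3C(COc4ccc(Cl)cc4F)[C@@H]3C2)nc2ccccc21` differs from compound 1 in one place: 4-chloro-2-fluorophenyl in place of phenyl on an oxygen on a saturated carbon. Among the measured compounds shown here, no step between two measured compounds exists here to set a scale for such a change, so the expectation rests on compound 1 alone. Compound 4 is expected to show a step from compound 1 of a 1.4-fold lower number from compound 1 to compound 4 (0.15 log units; within the scatter), towards slower clearance, but small enough that it may not exceed the usual scatter. Compound 4 is estimated at 10 mL/min/kg, with a range from 5.3 mL/min/kg to 20 mL/min/kg.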

Compound 4, clearance: 6.9 mL/min/kg
The estimate for compound 4 lay 1.4-fold (0.16 log units) above the measured number; low and high end bracket the measured number.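

In this assay, the place held by phenyl on the oxygen in compound 1 proves able to shift the read-out: 4-chloro-2-fluorophenyl there gives a 2.1-fold lower number from compound 1 to compound 4 (0.31 log units; beyond the scatter), a modest step towards slower clearance. Within the data shown here, the earlier compounds offered no pair of measured numbers, so this is the only step in the set that gives a size for a change at this place. The step is only just beyond the usual scatter, and the chlorine and the fluorine entered together, so the step cannot be divided between them.

As far as these compounds go, whether a phenyl ring carrying a methoxy group or a nitrile in place of these halogens would move the number in the same way remains open. How much lower the number could go can be followed only as far as a cut-off of the read-out: the limit of < 5.3 mL/min/kg in this assay, at which 1 of the 4 values shown sits.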